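The compounds below may be only part of what the source reports. "The series", "measured", "known", "first", "only" and "open" are said of these compounds alone.

Measured so far:
compound 1, `O=C(Nc1ccc(C(F)(F)F)cc1)c1cc(Cl)c(-c2ccccc2)cc1O` — 1160 nM
compound 2, `O=C(Nc1ccc(Br)c(Cl)c1)c1cc(F)ccc1O` — 860 nM

Of the compounds shown here, two have been measured in a functional assay on Jurkat cells (Homo sapiens) for cytotoxicity, read by luminescence and CellTiter-Glo, with a stated time of 3 days; a lower number here means a stronger inhibitor, a higher number a weaker inhibitor. Compound 1 gives 1160 nM, and compound 2 gives 860 nM. The two numbers sit within the usual scatter of each other, so neither compound can be placed ahead of the other on the evidence so far.

The next compound, compound 3 with the structure `O=C(Nc1ccc(C(F)(F)F)cc1)c1cc(Cl)ccc1O`, is not yet measured. It differs from compound 1 in one place: hydrogen in place of phenyl on an aromatic carbon. The phenyl on the core of compound 1 is removed and a hydrogen atom is left on that aromatic carbon.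

Among the measured compounds shown here, no step between measured compounds speaks to this change, and compound 2 shares no such pair with compound 1. The expectation therefore rests only on the loss of the phenyl itself. Compound 3 is expected to give 2500 nM in this assay, within a range from 800 nM to 8000 nM. The step from compound 1 to compound 3 is estimated at a 2.2-fold higher number from compound 1 to compound 3 (0.33 log units; beyond the scatter), toward a higher number and near the edge of the scatter.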

Compound 3, half-maximal inhibitory concentration: 710 nM
Beside the measured number, compound 3's estimate is 3.5-fold (0.55 log units) above it; measured number below the stated range.
By their numbers in this assay, from the lowest: compounds 3, 2 and 1 (each within the scatter of the next).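

In this assay, among the compounds shown here, replacing the phenyl with hydrogen on the aromatic carbon ortho to the chloro group and meta to the hydroxy group gives a 1.6-fold lower number from compound 1 to compound 3 (0.21 log units; within the scatter), the first direct reading at this position. The phenyl, with its six heavy atoms and whole aromatic ring, can therefore leave the core of compound 1 without the number moving beyond the scatter, so this single pair shows that the phenyl is not needed for a number of this size in this cytotoxicity read-out. Nothing available explains why the step is this small.

The compounds shown leave open whether any group on this aromatic carbon can shift the number beyond the scatter in either direction: a methyl group, an amine, a carboxylic acid or a longer chain could each be read against the hydrogen of compound 3. For the compounds shown here, they also leave open whether the same change would give a similar step with another group in place of the trifluoromethyl on the anilide ring, since only one pair speaks to this position.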